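The source may report more compounds than this note shows. Statements on the series, on what has been measured and on what is new or still open speak of the compounds shown alone.

In a functional assay on P388 cells (Mus musculus) for cytotoxicity (a lower number here means a stronger inhibitor, a higher number a weaker inhibitor), compound 1 `COC(=O)C[C@@H]1NC(=O)[C@@H](C)NC(=O)[C@@H]2Cc3ccc(OC)c(c3)Oc3ccc(cc3)C[C@@H](C(=O)N2C)N(C)C(=O)[C@H](C)NC(=O)[C@H](Cc2ccc(OC)cc2)N(C)C1=O` gives 41.7 nM, while compound 2 `COc1ccc(C[C@H]2C(=O)N[C@@H](C)C(=O)N(C)[C@H]3Cc4ccc(cc4)Oc4cc(ccc4OC)C[C@@H](C(=O)N[C@H](C)C(=O)N[C@@H](CSC(C)=O)C(=O)N2C)N(C)C3=O)cc1` gives 9.77 nM, the lower of the two numbers. Compound 3 `COc1ccc(C[C@H]2C(=O)N[C@@H](C)C(=O)N(C)[C@H]3Cc4ccc(cc4)Oc4cc(ccc4OC)C[C@@H](C(=O)N[C@H](C)C(=O)N[C@@H](CS)C(=O)N2C)N(C)C3=O)cc1` carries hydrogen in place of acetyl on a sulfur. Within the data shown here, only one measured step bears on this change, the modest 4.3-fold lower number from compound 1 to compound 2 (0.63 log units; beyond the scatter), which introduced the acetylsulfanyl group but does not test its loss of acetyl. On these data alone, no step beyond the scatter is therefore expected, and the direction remains open. Compound 3 is estimated at 13 nM, with an expected range from 3.5 nM to 50 nM. That estimate means an expected 1.3-fold higher number from compound 2 to compound 3 (0.12 log units; within the scatter).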

Compound 3, half-maximal inhibitory concentration: 363 nM
For compound 3 the middle estimate is 28-fold (1.45 log units) below the measured one, outside the stated range (above it).
By their numbers in this assay, from the lowest: compound 2; then compound 1; then compound 3.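

In this assay, the acetyl on the sulfur proves to matter: its replacement by hydrogen gives a 37-fold higher number from compound 2 to compound 3 (1.57 log units; beyond the scatter) and so reverses the gain seen with acetylsulfanyl. The free sulfanyl group also falls behind the methoxycarbonyl group, with an 8.7-fold higher number from compound 1 to compound 3 (0.94 log units; beyond the scatter), so the presence of sulfur alone does not give the lower number of compound 2. Nothing given here explains this difference. The compounds shown leave open whether another acyl group on the sulfur, such as propanoyl or benzoyl, would match acetyl. They also leave open how a methyl group on that sulfur would compare.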